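Methoxy to trifluoromethyl on the aryl ring of the shared core

A few compounds are considered here, and "the series" means these few. Any claim that something is new, unique, unknown or untested is made for them only; others in the source may bear on it.

Compound 1 `CCOC(=O)c1c(N)sc(-c2ccc(C(C)=O)cc2)c1-c1cccc(C(F)(F)F)c1` and compound 2 `CCOC(=O)c1c(N)sc(-c2ccc(OC)cc2)c1-c1cccc(C(F)(F)F)c1` share one core and are separated by a step that the two limits leave unreadable from compound 1 to compound 2. In a functional assay on CHO-K1 cells for agonist activity at adenosine receptor A1 (Homo sapiens), read by GTPgammaS binding (on this read-out higher numbers stand for an effect only at larger amounts of compound and lower numbers for an effect already at smaller amounts), compound 1 gives only a limit of the assay, > 10 uM. Compound 2 also gives only a limit, > 10 uM, in this assay. Both measured values thus sit at the limit of > 10 uM in this assay, at which 2 of the 2 values shown sit, so compound 2 stands at the limit and no number within the range is known for it.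

Compound 3 `CCOC(=O)c1c(N)sc(-c2ccc(C(F)(F)F)cc2)c1-c1cccc(C(F)(F)F)c1` differs from compound 2 by trifluoromethyl in place of methoxy on an aromatic carbon. Within the data shown here, the one measured step, from acetyl to methoxy, is unreadable because both ends are limits, so no measured step gives a size for the change now considered. Compound 3 is expected to stay near the limit, with an expected step that the limit leaves unreadable from compound 2 to compound 3. For compound 3 the estimated value in this assay is 20 uM, expected between 4 uM and 100 uM.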

Compound 3, concentration for half-maximal effect: > 10 uM
Compound 3 was reported as a limit; the forecaster's own chance of this, stated with the estimate: 75%; the middle value does not contradict the limit.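

Compound 1, compound 2 and compound 3 all give only a limit, so the steps among them cannot be read: the limit of > 10 uM in this assay, at which 3 of the 3 values shown sit.

Going by these compounds, whether acetyl, methoxy and trifluoromethyl differ at all in this assay stays open, since none of the three compounds gives a number.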